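Three Limits Reached, One Ether Still to Measure

The compounds below may be only part of what the source reports. "The series", "measured", "known", "first", "only" and "open" are said of these compounds alone.

Compound 2 `C=CCC(O)(c1ccc(OC)c(OC)c1OC)c1cccc2ccccc12` and compound 1 `COc1ccc(C(O)(Cc2ccc(C)cc2)c2cccc3ccccc23)c(OC)c1OC` share a core and differ by 4-methylphenyl in place of vinyl on a saturated chain carbon, two bonds along the chain from two aromatic carbons and an oxygen on a saturated carbon. In a functional assay on THP-1 cells (Homo sapiens) for inhibition, read by sulforhodamine B assay, with a stated time of 48 h (on this read-out higher numbers stand for weaker inhibition and lower numbers for stronger inhibition), compound 2 gives only a limit of the measurement, > 20000 nM. Compound 1 likewise stops at a limit, > 20000 nM. The step that the two limits leave unreadable from compound 2 to compound 1 therefore cannot be sized because of the limit of > 20000 nM in this assay, at which 3 of the 3 values shown sit. Compound 3 `C=CCOC(c1ccc(OC)c(OC)c1OC)c1cccc2ccccc12` is built from the same atoms as compound 2, joined differently; the difference between the two cores is not broken down here. In this assay compound 3 also reaches only a limit, > 20000 nM. Compound 4 `COc1ccc(C(OCc2ccc(C)cc2)c2cccc3ccccc23)c(OC)c1OC` differs from compound 3 by 4-methylphenyl in place of vinyl on a saturated chain carbon bound to an oxygen on a saturated carbon, the same kind of change, but here placed on a saturated chain carbon bound to an oxygen on a saturated carbon rather than two bonds along the chain from two aromatic carbons and an oxygen on a saturated carbon. Among the measured compounds shown here, with every value so far a limit, the step is expected to be roughly flat, a step that the limit leaves unreadable from compound 3 to compound 4. Compound 4 is expected to give about 30000 nM, most likely again only a limit.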

Compound 4, half-maximal inhibitory concentration: > 20000 nM
Compound 4: a limit, no number (the forecaster's own chance of this, stated with the estimate: 85%); the middle value is on the limit's open side.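

Compound 4 also stops at a limit, so no size can be read for its change from compound 3: the limit of > 20000 nM in this assay, at which 4 of the 4 values shown sit.

The compounds shown leave open whether 4-methylphenyl in place of vinyl changes anything in this assay at all, and what actual number any of them would give.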